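Swapping the aryl group on the piperazine of compound 2

The source may report more compounds than this note shows. Statements on the series, on what has been measured and on what is new or still open speak of the compounds shown alone.

Of the compounds shown here, two of a shared core have been measured so far. Compound 1, `CN1CCN(CC(=O)Nc2nc3ccccc3[nH]2)CC1`, gives 45% in a functional assay, read by spectrophotometry, with a stated time of 30 min, tested at 100 ug/mL; a higher number here means a stronger effect of the compound at the concentration tested, a lower number a weaker effect. Compound 2, `O=C(CN1CCN(c2ccccc2F)CC1)Nc1nc2ccccc2[nH]1`, gives 47.7% in the same assay, which places it highest of the two numbers, though its nearest neighbour is compound 1 and the difference is within the scatter.

The new compound 3, `O=C(CN1CCN(c2ccc([N+](=O)[O-])cc2)CC1)Nc1nc2ccccc2[nH]1`, differs from compound 2 by 4-nitrophenyl in place of 2-fluorophenyl on an amine nitrogen in a ring.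

Going by the values given here, only one measured step bears on this change, and it concerns the same ring nitrogen: a number 2.7 percentage points higher from compound 1 to compound 2 (within the scatter). That step swapped a methyl for an aryl group and moved the read-out by a distance within the scatter. Among the compounds with values here, the move from compound 2 to compound 3 swaps one aryl group for another at that same place, and no measured step shows what a nitro group does here. Within the data shown here, from the one step available, the expected result for compound 3 is a change of about a number 0.3 percentage points higher from compound 2 to compound 3 (within the scatter), none beyond the scatter. Compound 3 is therefore estimated at 48%, within a range from 35% to 62%.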

Compound 3, a percentage reported as activity, at one concentration (the size of the read-out at that concentration, not a potency): 51.7%
Compound 3: middle estimate off by 3.7 percentage points, on the low side; the measured number falls inside the stated range.
By their numbers in this assay, from the lowest: compounds 1, 2 and 3 (each within the scatter of the next).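

In this assay, exchanging the 2-fluorophenyl group on the ring nitrogen for 4-nitrophenyl gives a number 4 percentage points higher from compound 2 to compound 3 (within the scatter) and so shows that this position tolerates a second, larger aryl group, one that brings in a nitro group with its 2 hydrogen-bond acceptors, without a step beyond the scatter. The longer comparison, from the small methyl group to the same 4-nitrophenyl group, gives a number 6.7 percentage points higher from compound 1 to compound 3 (within the scatter) and is also within the scatter, so methyl, 2-fluorophenyl and 4-nitrophenyl cannot be told apart on this read-out, even though they differ considerably in size and make-up. Nothing available here explains why such different groups on this nitrogen give readings this close.

Still open, going by these compounds, is whether any group on this ring nitrogen can move the reading beyond the scatter, for example a benzyl group, an acetyl group or a chain ending in a carboxylic acid. A 4-fluorophenyl or 2-nitrophenyl group would also be needed to separate the identity of the substituent on the aryl ring from its place on that ring.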